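A few compounds are considered here, and "the series" means these few. Any claim that something is new, unique, unknown or untested is made for them only; others in the source may bear on it.

Working notes on the series. In a functional assay on HEK293 cells for agonist activity at D(4) dopamine receptor (Homo sapiens), read by FLIPR (on this read-out higher numbers stand for larger maximal responses and lower numbers for smaller maximal responses), compound 3 `O=C(CN1CCC(c2cccc[n+]2[O-])CC1)NC1CCCCC1` gives 58%, the lowest of the three numbers recorded so far. Compound 1 `CCc1cccc(NC(=O)CN2CCC(c3cccc[n+]3[O-])CC2)c1` gives 62%, which lies within the scatter of compound 3. Compound 2 `O=C(CN1CCC(c2cccc[n+]2[O-])CC1)Nc1ccc(F)cc1F` gives 74%, beyond the scatter of compound 3. Compound 4 `O=C(CN1CCC(c2cccc[n+]2[O-])CC1)Nc1cc(Cl)cc(Cl)c1` has not been measured. Its change from compound 3 is 3,5-dichlorophenyl in place of cyclohexyl on an amide-type nitrogen. Going by the values given here, two measured steps bear on this: a number 16 percentage points lower from compound 2 to compound 3 (beyond the scatter) and a number 4 percentage points lower from compound 1 to compound 3 (within the scatter). Both run toward cyclohexyl, one beyond the scatter and one within it, so for compound 4 the reverse direction is expected to bring a modest rise in this assay, about a number 10 percentage points higher from compound 3 to compound 4 (within the scatter). The estimate for compound 4 in this assay is 68%, with a range from 55% to 82%.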

Compound 4, largest response reached (reported as efficacy), in percent of the reference or control that the assay uses: 68%
For compound 4 middle estimate and measured number coincide at the digits printed; the measured number falls inside the stated range.
By their numbers in this assay, from the lowest: compounds 3, 1, 4 and 2 (each within the scatter of the next, the first and the last beyond it).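

In this assay, 3,5-dichlorophenyl on the amide-type nitrogen stands within the scatter of all three other groups (a number 10 percentage points higher from compound 3 to compound 4 (within the scatter); a number 6 percentage points higher from compound 1 to compound 4 (within the scatter); a number 6 percentage points lower from compound 2 to compound 4 (within the scatter)). Compound 2 and compound 3 remain separated beyond the scatter, yet compound 4 cannot be told apart from either, so this change gives no clear separation between the aromatic and non-aromatic groups at this position. No available evidence accounts for these steps.

Open, from the compounds shown here alone, is how an amine or a carboxylic acid on the aromatic ring, or a longer chain on the amide-type nitrogen, would compare with these groups.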